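A few compounds are considered here, and "the series" means these few. Any claim that something is new, unique, unknown or untested is made for them only; others in the source may bear on it.

In an ADME assay on Karpas-1106P cells (Homo sapiens) for cytotoxicity (a higher number here means that more compound is needed for the effect, a lower number that less compound is needed), compound 3 `Cc1ccc(S(=O)(=O)N[C@@H](CC(=O)NC(C)(C)C)C(=O)NCCNC(=O)c2cc(Cl)ccc2Cl)cc1` gives > 11100 nM as its result, and this is a limit of the assay, not a number. Compound 1 `Cc1ccc(S(=O)(=O)N[C@@H](CC(=O)NC(C)(C)C)C(=O)NCCNC(=O)c2cc(Cl)ccn2)cc1` gives > 11100 nM as its result, again a limit. Compound 2 `Cc1ccc(S(=O)(=O)N[C@@H](CC(=O)NC(C)(C)C)C(=O)NCCNC(=O)c2cccc(O)c2)cc1` gives > 11100 nM as its result, also a limit. The whole picture so far is the limit of > 11100 nM in this assay, at which 3 of the 3 values shown sit, and nothing finer. Compound 4 `Cc1ccc(S(=O)(=O)N[C@@H](CC(=O)NC(C)(C)C)C(=O)NCCNC(=O)c2cc(C)ccn2)cc1` carries 4-methylpyridin-2-yl in place of 2,5-dichlorophenyl on a carbonyl carbon, and the full count reads 4-methylpyridin-2-yl in place of 2,5-dichlorophenyl on a carbonyl carbon for this swap. The measured steps change this same group, yet none has a size: a step that the two limits leave unreadable from compound 1 to compound 3 is one, a step that the two limits leave unreadable from compound 2 to compound 3 is another, and a step that the two limits leave unreadable from compound 1 to compound 2 is the third. Going by a step that the two limits leave unreadable from compound 1 to compound 3 as the nearest guide, no step beyond the scatter is expected in this assay and another limit is the likely report. The expected change is a step that the limit leaves unreadable from compound 3 to compound 4 as estimated here. For compound 4 the estimate is 15000 nM with an expected range from 7000 nM to 30000 nM overall.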

Compound 4, half-maximal effective concentration: > 11100 nM
Compound 4 was reported as a limit; the forecaster's own chance of this, stated with the estimate: 90%; the middle value does not contradict the limit.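

In this assay compound 4 gives > 11100 nM, a limit and not a number. Its steps to compound 1, compound 2 and compound 3 therefore cannot be read: the limit of > 11100 nM in this assay, at which 4 of the 4 values shown sit. The compounds shown leave open whether any of these groups on the carbonyl carbon changes the result in this assay at all.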